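Ethoxy for Methyl on the Aryl Ring of Compound 2

The source may hold more compounds than are shown below. What is called first, only, known or untested is meant among the compounds shown, and "the series" means these compounds.

Measured compounds:
compound 1, `CCc1nc(NC(CC)CC)c(Cl)nc1-c1ccc(Cl)cc1Cl`: 71 nM
compound 2, `CCc1nc(-c2ccc(C)cc2OC)c(CC)nc1NC(CC)CC`: 23.7 nM

Both were tested in an assay on IMR-32 cells for displacement of a labelled ligand from corticotropin-releasing factor receptor 1 (Homo sapiens), read by scintillation counting, with a stated time of 2 h; on this read-out lower numbers stand for stronger inhibition and higher numbers for weaker inhibition. Compound 1 gives 71 nM, while compound 2 gives 23.7 nM, the lower of the two numbers, and the gap between them lies beyond the usual scatter. Compound 3, `CCOc1ccc(-c2nc(CC)c(NC(CC)CC)nc2CC)c(OC)c1`, differs from compound 2 by ethoxy in place of methyl on an aromatic carbon. Among the compounds with values here, no measured pair shows this kind of change, so no shift beyond the scatter is expected in either direction; the estimated step is a 1.1-fold higher number from compound 2 to compound 3 (0.02 log units; within the scatter). Compound 3 is expected to give 25 nM, with a range from 8 nM to 80 nM.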

Compound 3, inhibition constant: 7.8 nM
Compound 3: the middle estimate sits 3.2-fold (0.51 log units) above what was measured; the measured number lies below the stated range.
By their numbers in this assay, from the lowest: compound 3; then compound 2; then compound 1.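

The aromatic carbon meta to a methoxy group and para to a large group accepts a group larger than methyl in this assay: ethoxy in place of methyl gives a 3.0-fold lower number from compound 2 to compound 3 (0.48 log units; beyond the scatter) and so marks this position as one where a change can move the number beyond the scatter. Within the data shown here, this is the first step read at this position. Nothing available explains the drop.

As far as these compounds go, the role of the added oxygen stays open, as does the effect of chain length. An ethyl group or a longer propoxy chain at this carbon could give a number close to that of compound 3 or far from it.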